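This account rests on a few compounds, and the source may have more. Where it says the series, first, only, none or still open, it means among the compounds named here.

Compound 1 `Cc1cc2ncccc2cc1Nc1ncc2c(n1)n(C1CCOCC1)c(=O)n2C`: 2.5
Compound 2 `Cc1cc2ncncc2cc1Nc1ncc2c(n1)n(C1CCOCC1)c(=O)n2C`: 2.2
Compound 3 `Cc1cc2ncccc2cc1Nc1ncc2c(n1)n(C1CCN(C)CC1)c(=O)n2C`: 1.8

In a physicochemical assay for lipophilicity, read by HPLC, using the shake flask method, measured as octanol-water partition, at pH 7.4 (on this read-out higher numbers stand for higher lipophilicity and lower numbers for lower lipophilicity), compound 3 gives the lowest of these three numbers, and both others stand higher, beyond the usual scatter. Compound 4 `Cc1cc2ncccc2cc1Nc1ncc2c(n1)n([C@@H]1CCN(C)C1)c(=O)n2C` differs from it in one place: 1-methylpyrrolidin-3-yl in place of 1-methylpiperidin-4-yl on an aromatic nitrogen. Thus 1-methylpyrrolidin-3-yl replaces 1-methylpiperidin-4-yl on an aromatic nitrogen. For the measured compounds named here, no measured step makes this exact swap. The closest evidence is a number 0.70 log units lower from compound 1 to compound 3 (beyond the scatter), a modest change at the same place, but it swaps a different group and so gives no firm direction here. Only a small downward move is therefore expected, quite possibly within the scatter. The estimated step is a number 0.20 log units lower from compound 3 to compound 4 (within the scatter). Compound 4 is expected at 1.6, within an estimated range from 1.2 to 2.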

Compound 4, distribution coefficient: 1.2
Estimate against measurement, compound 4: 0.40 log units above; low and high end bracket the measured number.
By their numbers in this assay, from the lowest: compound 4; then compound 3; then compounds 2 and 1 (each within the scatter of the next).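

Replacing 1-methylpiperidin-4-yl with 1-methylpyrrolidin-3-yl gives a number 0.60 log units lower from compound 3 to compound 4 (beyond the scatter) in this assay even though both groups are methylated rings with one nitrogen, so the read-out at this position responds to a change in ring size alone. Set against oxan-4-yl, the five-membered group gives a number 1.30 log units lower from compound 1 to compound 4 (beyond the scatter) as the largest step at this position so far.

Still open, going by these compounds, is how the mirror-image form of 1-methylpyrrolidin-3-yl, an azetidine ring or a piperidine ring without the methyl group would compare. Nothing further is available to explain this result.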